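This account rests on a few compounds, and the source may have more. Where it says the series, first, only, none or still open, it means among the compounds named here.

Compound 3 `CC1(C)[C@@H]2CC[C@@]1(C)/C(=N/NC(=O)c1ccccc1)C2` stands at the top of the range seen so far. In an ADME assay on MDCK cells (Canis lupus familiaris) for cytotoxicity, read by MTT assay, with a stated time of 48 h (a higher number here means that more compound is tolerated, a lower number that less compound is tolerated), compound 3 gives > 1040000 nM, which is a limit of the assay rather than a number. Compound 1 `CC1(C)[C@@H]2CC[C@@]1(C)/C(=N/NC(=O)c1cccs1)C2` gives 1030000 nM in this assay. Compound 2 `CC1(C)[C@@H]2CC[C@@]1(C)/C(=N/NC(=O)C(F)(F)F)C2` gives > 1070000 nM, again a limit. The steps between them are small or unreadable: an at least 1.0-fold higher number from compound 1 to compound 2 (0.01 log units; that floor lies within the scatter), a number no lower from compound 1 to compound 3 (the limit leaves the size open), and a step that the two limits leave unreadable from compound 2 to compound 3. Compound 4 `CC1(C)[C@@H]2CC[C@@]1(C)/C(=N/NC(=O)c1ccco1)C2` differs from compound 3 by furan-2-yl in place of phenyl on a carbonyl carbon. Since the measured steps among compounds 1, 2 and 3 show nothing beyond the scatter, compound 4 is expected to show no step beyond the scatter either, an at least 1.0-fold lower number from compound 3 to compound 4 (0.01 log units; that floor lies within the scatter). Compound 4 is therefore estimated at 1000000 nM, within 500000 nM to 1100000 nM.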

Compound 4, half-maximal cytotoxic concentration: 1090000 nM
Estimate against measurement, compound 4: 1.1-fold (0.04 log units) below; the range from low to high includes it.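

In this assay, for the compounds shown here, changing the group on the carbonyl carbon gives a 1.1-fold higher number from compound 1 to compound 4 (0.02 log units; within the scatter), the first step at this position with a number at both ends. The steps from compound 2 and from compound 3 to compound 4 cannot be read: those two compounds carry only limits of the assay.

The compounds shown leave open whether any group at this place lowers the number beyond the scatter. As far as these compounds go, a group carrying an amine or a carboxylic acid, or a longer chain, remains untested here.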